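Swapping Amino for Nitro at the Cytotoxicity Ceiling

The compounds below may be only part of what the source reports. "The series", "measured", "known", "first", "only" and "open" are said of these compounds alone.

Compound 1 `Cc1ccccc1-c1nn(C(C)C)cc1CNCCN1CCN(C)CC1` and compound 2 `Cc1ccccc1-c1nn(-c2ccc(N)cc2)cc1CNCCN1CCN(C)CC1` share one core and differ only in the group carried on an aromatic nitrogen. In an ADME assay on Huh-7 cells (Homo sapiens) for cytotoxicity (a higher number here means that more compound is tolerated, a lower number that less compound is tolerated), compound 1 reaches only the limit of the measurement, > 20000 nM. Compound 2 likewise gives only a limit, > 20000 nM. The step that the two limits leave unreadable from compound 1 to compound 2 therefore has no readable size. Compound 2 thus stands at the ceiling of what was measured, with no number beneath it to compare against. Compound 3 `Cc1ccccc1-c1nn(-c2ccc([N+](=O)[O-])cc2)cc1CNCCN1CCN(C)CC1` differs from compound 2 by nitro in place of amino on an aromatic carbon. For the measured compounds named here, the single measured step is the only evidence that bears on this change, and it cannot be sized; what is known is the limit of > 20000 nM in this assay, at which 2 of the 2 values shown sit. Compound 3 is therefore expected to remain at or near the same ceiling, and the step is estimated as a step that the limit leaves unreadable from compound 2 to compound 3, meaning nothing beyond the scatter. Compound 3 is estimated at 25000 nM, within a range from 10000 nM to 60000 nM.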

Compound 3, half-maximal cytotoxic concentration: > 20000 nM
Compound 3: only a limit was reported; the forecaster's own chance of this, stated with the estimate: 70%; the middle value lies beyond the limit too.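

For the compounds shown here, compound 3 also ends at a limit, so no step among compound 1, compound 2 and compound 3 can be read: the limit of > 20000 nM in this assay, at which 3 of the 3 values shown sit. Left open is where each compound's half-maximal cytotoxic concentration actually lies in this assay and whether these group changes make any difference.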